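Dropping one methoxy group from a cytotoxic chalcone-pyrazole

The source may hold more compounds than are shown below. What is called first, only, known or untested is meant among the compounds shown, and "the series" means these compounds.

Measured compounds:
compound 1, `COc1cc(-c2cc(/C=C/C(=O)c3ccc(Cl)c(Cl)c3)[nH]n2)cc(OC)c1OC`, 102%
compound 2, `COc1ccc(C(=O)/C=C/c2cc(-c3cc(OC)c(OC)c(OC)c3)n[nH]2)cc1OC`, 99%

In a functional assay on HCT-116 cells (Homo sapiens) for cytotoxicity, read by sulforhodamine B assay, with a stated time of 48 h, tested at 0.01 uM (a lower number here means a stronger effect, a higher number a weaker effect of the compound at the concentration tested), compound 1 gives 102%, and compound 2 gives 99%. Going by the values given here, the two numbers lie within the scatter of each other, so compound 2 stands level with compound 1 rather than apart from it; the only measured step, a number 3 percentage points lower from compound 1 to compound 2 (within the scatter), confirms this.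

Compound 3, `COc1ccc(C(=O)/C=C/c2cc(-c3cc(OC)c(OC)c(OC)c3)n[nH]2)cc1`, differs from compound 2 by hydrogen in place of methoxy on an aromatic carbon; read one bond further out, the change is 3,4-dimethoxyphenyl to 4-methoxyphenyl. Among the compounds with values here, no measured step touches this exact change. Within the data shown here, the one step available, from the dichloro to the dimethoxy ring, left the read-out unchanged, and both measured compounds sit near the level of no effect at this concentration. A step no larger than the scatter is therefore expected for a number 1 percentage points higher from compound 2 to compound 3 (within the scatter). Compound 3 is estimated at 100%, with a range from 90% to 110%.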

Compound 3, a percentage reported as activity, at one concentration (the size of the read-out at that concentration, not a potency): 100%
The estimate for compound 3 equals the measured number at the digits printed; low and high end bracket the measured number.
By their numbers in this assay, from the lowest: compounds 2, 3 and 1 (each within the scatter of the next).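

Hydrogen in place of the methoxy group, ortho to a methoxy group on this ring, leaves the read-out level in this assay: the step is a number 1 percentage points higher from compound 2 to compound 3 (within the scatter), so at this concentration the second methoxy group makes no visible difference. The 4-methoxyphenyl ring also stands level with the 3,4-dichlorophenyl ring, with a number 2 percentage points lower from compound 1 to compound 3 (within the scatter) as the step. All three compounds sit near the level of no effect, so this flat result says little about how much the position can matter.

The compounds shown leave open whether a hydroxyl group or an amine on this aromatic carbon would move the read-out, and whether the three compounds would separate at another concentration. Nothing given here explains the level read-out.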